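The source may hold more compounds than are shown below. What is called first, only, known or untested is meant among the compounds shown, and "the series" means these compounds.

Measured so far:
compound 1 `Cn1ccc(-c2ccc(Cn3cc(C(=O)N[C@H]4CCCC[C@@H]4O)c4ncccc43)cc2)n1` — 47 mL/min/kg
compound 2 `N#Cc1ccc(Cn2cc(C(=O)N[C@H]3CCCC[C@@H]3O)c3ncccc32)cc1` — 18 mL/min/kg

In an ADME assay on liver for metabolic stability, with Liver microsome (Homo sapiens) as the target, using microsomes (a lower number here means slower removal, a higher number faster removal of the compound), compound 1 gives 47 mL/min/kg and compound 2 gives 18 mL/min/kg. Of these two numbers, compound 2 holds the lowest; its nearest neighbour is compound 1, and the step of a 2.6-fold lower number from compound 1 to compound 2 (0.42 log units; beyond the scatter) lies beyond the usual scatter.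

Compound 3 `O=C(N[C@H]1CCCC[C@@H]1O)c1cn(Cc2ccc3ncccc3c2)c2cccnc12` has not been measured in this assay. It differs from compound 2 by quinolin-6-yl in place of 4-cyanophenyl on a saturated chain carbon bound to an aromatic nitrogen. For the measured compounds named here, the only measured step that bears on this change is a 2.6-fold lower number from compound 1 to compound 2 (0.42 log units; beyond the scatter), where a larger aromatic substituent at that end of the molecule went with the higher number and the nitrile with the lower one. By that one comparison, a move from the nitrile-bearing ring of compound 2 to the quinolin-6-yl of compound 3 is expected to give a modest rise, a 1.7-fold higher number from compound 2 to compound 3 (0.22 log units; within the scatter), though a single step is a thin basis. Compound 3 is therefore expected to come in near 30 mL/min/kg, within a range of 15 mL/min/kg to 60 mL/min/kg.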

Compound 3, clearance: 87 mL/min/kg
Estimate against measurement, compound 3: 2.9-fold (0.46 log units) below; measured number outside the range, above it.
By their numbers in this assay, from the lowest: compound 2; then compounds 1 and 3 (each within the scatter of the next).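

In this assay, quinolin-6-yl in place of 4-cyanophenyl on the saturated chain carbon bound to an aromatic nitrogen gives a 4.8-fold higher number from compound 2 to compound 3 (0.68 log units; beyond the scatter) and so undoes the low number of compound 2. For the compounds shown here, compound 3 now stands within the scatter of compound 1, so two quite different aromatic groups at this position give numbers that cannot be told apart, and among the three compounds only the one with 4-cyanophenyl stands clearly lower. Nothing at hand accounts for this difference.

The compounds shown leave open whether the low number goes with the nitrile itself or with the plain benzene ring that carries it, which an unsubstituted phenyl or a quinolin-6-yl bearing a nitrile would separate. Also open, on these data alone, is whether a carboxylic acid or an amine in the nitrile's place would keep the number as low.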